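The source may hold more compounds than are shown below. What is called first, only, known or untested is meant among the compounds shown, and "the series" means these compounds.

Working notes on the dithiocarbamate-linked series.

Three compounds have numbers in a functional assay on HEp-2 cells (Homo sapiens) for antiproliferative activity, read by MTT assay, with a stated time of 72 h; a lower number here means a stronger inhibitor, a higher number a weaker inhibitor. Compound 1 `CCN(CC)C(=S)SCc1cc(=O)c2ccc(Cl)cc2o1` gives 8800 nM and stands at the highest number of the three. Compound 3 `O=c1c(CSC(=S)N2CCOCC2)coc2ccccc12` gives 4400 nM in this assay, and its gap to compound 1 lies within the scatter, so the two cannot be ordered. Compound 2 `Cc1ccc2c(=O)c(CSC(=S)N3CCCC3)coc2c1` gives 3600 nM in this assay, and here the gap to compound 1 lies beyond the scatter, compound 2 sitting at the lower number. Among the compounds with values here, no two of the three differ in a single place, so no single step is available from which to read an effect.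

Compound 4 `CC(C)N(C(=S)SCc1cc(=O)c2ccc(Cl)cc2o1)C(C)C` is unmeasured. It differs from compound 1 in one place: diisopropylamino in place of diethylamino on a thiocarbonyl carbon. Nothing in the three measured compounds speaks to this change on the thiocarbonyl carbon, since their variation lies elsewhere. The step from compound 1 to compound 4 is therefore expected to be small, a 1.1-fold lower number from compound 1 to compound 4 (0.04 log units; within the scatter), in no clear direction, and not beyond the scatter. Compound 4 is estimated at 8000 nM in this assay, within a range of 3500 nM to 18000 nM.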

Compound 4, half-maximal inhibitory concentration: 22700 nM
The estimate for compound 4 lay 2.8-fold (0.45 log units) below the measured number, and the stated range ends below it.
By their numbers in this assay, from the lowest: compounds 2, 3 and 1 (each within the scatter of the next, the first and the last beyond it); then compound 4.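

The amino group on the thiocarbonyl carbon is not a silent place in this assay: diisopropylamino in place of diethylamino gives a 2.6-fold higher number from compound 1 to compound 4 (0.41 log units; beyond the scatter). Within the data shown here, this is the first single-place step, and it shows that a change confined to this position, with the rest of compound 1 held fixed, can move the number by a modest but readable amount. No measurement on hand bears on what lies behind this step.

From the compounds shown here alone, whether the higher number follows branching or the larger group in general stays open, as a single pair cannot separate the two, whereas dimethylamino or dipropylamino on the thiocarbonyl carbon would help to do so. Also open, going by these compounds, is whether the same change would give a similar step on the cores of compound 2 and compound 3.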